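Swapping a Ring for Two Ethyl Groups

A few compounds are considered here, and "the series" means these few. Any claim that something is new, unique, unknown or untested is made for them only; others in the source may bear on it.

Compound 1 `C=C[C@]1(C)CC[C@@H](C(=C)CNCCCC)C[C@H]1C(=C)C`: 10800 nM
Compound 2 `C=C[C@]1(C)CC[C@@H](C(=C)CNC2CCCC2)C[C@H]1C(=C)C`: 520 nM

Both numbers come from a functional assay on HeLa cells (Homo sapiens) for antiproliferative activity, read by WST assay, with a stated time of 24 h; a lower number here means a stronger inhibitor, a higher number a weaker inhibitor. Going by the values given here, compound 2 has the lower of the two, and the gap to compound 1, its only neighbour so far, lies beyond the scatter. Compound 3 `C=C[C@]1(C)CC[C@@H](C(=C)CN(CC)CC)C[C@H]1C(=C)C` has not yet been measured. It differs from compound 2 in one place: diethylamino in place of cyclopentylamino on a saturated chain carbon bound to a double-bonded chain carbon. Put simply, diethylamino stands in place of cyclopentylamino on a saturated chain carbon bound to a double-bonded chain carbon.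

Among the compounds with values here, only one measured step bears on this change: a 21-fold lower number from compound 1 to compound 2 (1.32 log units; beyond the scatter). This large step came with cyclopentyl in place of butyl on an amine nitrogen, so the group on that nitrogen can shift the number strongly. It is a single pair, however, and a thin basis for any forecast. Like compound 1 (10800 nM), compound 3 carries open chains and no ring there, so a clear move towards a higher number in this assay seems likely. The expected change is a 5.8-fold higher number from compound 2 to compound 3 (0.76 log units; beyond the scatter). The estimated value for compound 3 is 3000 nM, with an expected range of 700 nM to 12000 nM.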

Compound 3, half-maximal inhibitory concentration: 14400 nM
Compound 3: the middle estimate sits 4.8-fold (0.68 log units) below what was measured; the measured number lies above the stated range.
By their numbers in this assay, from the lowest: compound 2; then compounds 1 and 3 (each within the scatter of the next).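

In this assay, replacing cyclopentylamino with diethylamino gives a 28-fold higher number from compound 2 to compound 3 (1.44 log units; beyond the scatter), so this position responds strongly not just to a single butyl chain on the nitrogen but also to two ethyl groups. The other comparison, a 1.3-fold higher number from compound 1 to compound 3 (0.12 log units; within the scatter), shows that diethylamino and butylamino cannot be told apart here, even though their open chains are arranged differently on the nitrogen; among these three compounds, only compound 2, the one with a ring on the nitrogen, stands apart, though three compounds are too few to support a general rule. Nothing measured here explains why compound 2 differs from the two open-chain compounds.

On these data alone, it remains open whether the five-membered carbon ring is special or whether other rings on this nitrogen would serve as well, such as cyclobutyl, cyclohexyl, or a pyrrolidine ring that contains the nitrogen itself. A small branched open group such as isopropyl would help show whether a closed ring is needed at all or whether branching at the carbon bound to the nitrogen is enough.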